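From 3-methoxyphenyl to 3,4-dichlorophenyl: what to expect

The compounds below may be only part of what the source reports. "The series", "measured", "known", "first", "only" and "open" are said of these compounds alone.

In an ADME assay on HEK293 cells (Homo sapiens) for cytotoxicity, read by MTT assay, with a stated time of 48 h (a lower number here means a stronger inhibitor, a higher number a weaker inhibitor), compound 1 `COc1ccc(-c2nc(C)c(C(=O)CSc3nc(N)c(C#N)c(-c4ccccc4)n3)s2)cc1` has the entry "not determined" (no result reported) and offers no number. Going by the values given here, compound 2 `COc1ccc(-c2nc(C)c(C(=O)CSc3nc(-c4cccc(OC)c4)c(C#N)c(=O)[nH]3)s2)cc1` gives 95400 nM here, and compound 3 `COc1cccc(-c2nc(SCC(=O)c3sc(-c4ccccc4)nc3C)[nH]c(=O)c2C#N)c1` gives 90200 nM here, so compound 2 sits within the scatter of its only measured neighbour. Compound 4 `COc1ccc(-c2nc(C)c(C(=O)CSc3nc(-c4ccc(Cl)c(Cl)c4)c(C#N)c(=O)[nH]3)s2)cc1` is still unmeasured. It carries 3,4-dichlorophenyl in place of the 3-methoxyphenyl of compound 2, a change counted as 3,4-dichlorophenyl in place of 3-methoxyphenyl on an aromatic carbon on an aromatic carbon. Among the compounds with values here, the only measured step, a 1.1-fold lower number from compound 2 to compound 3 (0.02 log units; within the scatter) in size, puts hydrogen in place of methoxy elsewhere and does not test this swap. No step beyond the scatter is therefore expected in this assay, and the estimated change, a 1.4-fold lower number from compound 2 to compound 4 (0.13 log units; within the scatter) in all, stays small. Compound 4 is expected at 70000 nM as a middle value, with an estimated range from 25000 nM to 130000 nM for repeat measurements.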

Compound 4, half-maximal inhibitory concentration: 45600 nM
For compound 4 the middle estimate is 1.5-fold (0.19 log units) above the measured one, and the stated range covers the measured number.
By their numbers in this assay, from the lowest: compounds 4, 3 and 2 (each within the scatter of the next, the first and the last beyond it).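

In this assay, putting 3,4-dichlorophenyl in place of 3-methoxyphenyl gives a 2.1-fold lower number from compound 2 to compound 4 (0.32 log units; beyond the scatter), a modest step that lies just beyond the scatter. This is the only measured change shown at this position, on the aromatic carbon ortho to a cyano group, and it shows that the group placed here can shift the number. Nothing measured here says what lies behind the step. The swap removes the methoxy and adds two chlorines together, and the compounds shown do not separate these two changes. A phenyl carrying a single chlorine, or an amine on that ring, remains an open comparison at this position.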